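Triazole series: replacing the nitrophenyl in compound 3

This account rests on a few compounds, and the source may have more. Where it says the series, first, only, none or still open, it means among the compounds named here.

Within the data shown here, compound 3 `COc1cc(/C=C/C(C)=O)ccc1OCc1cn(-c2ccc([N+](=O)[O-])cc2)nn1` stands at the high end of the three numbers so far: in a functional assay on PC-3 cells (Homo sapiens) for antiproliferative activity, read by MTT assay, with a stated time of 48 h (a higher number here means a weaker inhibitor, a lower number a stronger inhibitor), compound 3 gives 46700 nM, the highest of the three, and its steps to compound 2 and to compound 1 are both beyond the scatter. Compound 1 `COc1ccc(-n2cc(COc3ccc(/C=C/C(C)=O)cc3OC)nn2)cc1` gives 2010 nM in this assay, and compound 2 `COc1cc(/C=C/C(C)=O)ccc1OCc1cn(-c2ccccc2OC)nn1` gives 2050 nM; the two values sit within the scatter of each other, a 1.0-fold higher number from compound 1 to compound 2 (0.01 log units; within the scatter).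

Compound 4 `COc1cc(/C=C/C(C)=O)ccc1OCc1cn(-c2cc(F)cc(Br)c2)nn1` differs from compound 3 by 3-bromo-5-fluorophenyl in place of 4-nitrophenyl on an aromatic nitrogen. The aryl group on the triazole nitrogen loses its nitro substituent and takes up a bromine and a fluorine instead.

Among the measured compounds shown here, two measured steps bear on this change. Both involve the nitro group: a 23-fold higher number from compound 1 to compound 3 (1.37 log units; beyond the scatter), and a 23-fold higher number from compound 2 to compound 3 (1.36 log units; beyond the scatter). Whenever the 4-nitrophenyl is present, the number is much higher; whenever it is absent, the number falls back to the region of compound 1 and compound 2. As far as these compounds go, no halogenated aryl has been measured, so the size of any further shift from bromine and fluorine is unknown.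

Compound 4 is therefore expected to show a step down from compound 3 of roughly a 9.3-fold lower number from compound 3 to compound 4 (0.97 log units; beyond the scatter), landing near 5000 nM, estimated between 1500 nM and 16000 nM.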

Compound 4, half-maximal inhibitory concentration: 56900 nM
The estimate for compound 4 lay 11-fold (1.06 log units) below the measured number; the measured number lies above the stated range.
By their numbers in this assay, from the lowest: compounds 1 and 2 (each within the scatter of the next); then compounds 3 and 4 (each within the scatter of the next).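

In this assay, removing the 4-nitrophenyl does not by itself bring the number down: the change to 3-bromo-5-fluorophenyl gives a 1.2-fold higher number from compound 3 to compound 4 (0.09 log units; within the scatter), so the high number at this position is not tied to the nitro group alone. Measured against the methoxyphenyl compounds, the halogenated aryl stands as far off as the nitro aryl, with a 28-fold higher number from compound 2 to compound 4 (1.44 log units; beyond the scatter) and a 28-fold higher number from compound 1 to compound 4 (1.45 log units; beyond the scatter); the four compounds thus split into a methoxyphenyl pair with low numbers and a nitro and bromo-fluoro pair with high numbers, and none of the four goes against this split. No measurement at hand accounts for that split.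

Still open, as far as these compounds go, is whether the low numbers belong to the methoxy group specifically or would also appear with a plain phenyl, a hydroxyphenyl or an aminophenyl on the triazole nitrogen. Equally open, from the compounds shown here alone, is whether a phenyl carrying only the bromine or only the fluorine would sit with the high pair or the low pair.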